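Swapping Chloro for a Thiadiazolyl Sulfanyl Group

This account rests on a few compounds, and the source may have more. Where it says the series, first, only, none or still open, it means among the compounds named here.

Compound 1, `Cn1c(-c2ccc(NC(=O)CCl)cc2)nc(-c2ccccc2)c1-c1ccccc1`: 70%
Compound 2, `Cn1c(-c2ccc(NC(=O)CSc3nc4ccccc4s3)cc2)nc(-c2ccccc2)c1-c1ccccc1`: 76.6%
Compound 3, `Cn1nnnc1SCC(=O)Nc1ccc(-c2nc(-c3ccccc3)c(-c3ccccc3)n2C)cc1`: 77.7%

In a functional assay on MCF7 cells (Homo sapiens) for cytotoxicity, read by MTT assay, with a stated time of 24 h, tested at 80 ug/mL (a higher number here means a stronger effect of the compound at the concentration tested, a lower number a weaker effect), compound 1 shows the lowest of the three numbers, but the steps of a number 6.6 percentage points higher from compound 1 to compound 2 (within the scatter) and a number 7.7 percentage points higher from compound 1 to compound 3 (within the scatter) both stay within the scatter, so the three compounds cannot be told apart. Compound 4, `Cc1nnc(SCC(=O)Nc2ccc(-c3nc(-c4ccccc4)c(-c4ccccc4)n3C)cc2)s1`, differs from compound 1 in one place: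

(5-methyl-1,3,4-thiadiazol-2-yl)sulfanyl in place of chloro on a saturated chain carbon bound to a carbonyl carbon

The two measured steps that replace the chloro with a sulfanyl-linked ring bear directly on this change, and neither moved the read-out beyond the scatter. A step of similar size, if any, is therefore expected here: a number 5 percentage points higher from compound 1 to compound 4 (within the scatter). Compound 4 is estimated at 75%, with a range from 62% to 88%.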

Compound 4, a percentage reported as activity, at one concentration (the size of the read-out at that concentration, not a potency): 85.2%
Estimate against measurement, compound 4: 10.2 percentage points below, and the stated range covers the measured number.
By their numbers in this assay, from the lowest: compounds 1, 2, 3 and 4 (each within the scatter of the next, the first and the last beyond it).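

In this assay, for the compounds shown here, the (5-methyl-1,3,4-thiadiazol-2-yl)sulfanyl group gives the first step on this saturated chain carbon that clears the scatter (a number 15.2 percentage points higher from compound 1 to compound 4 (beyond the scatter)). It does not separate compound 4 from the other sulfanyl-linked rings (a number 7.5 percentage points higher from compound 3 to compound 4 (within the scatter); a number 8.6 percentage points higher from compound 2 to compound 4 (within the scatter)), so only the chloro compound stands apart from it. Nothing available explains this step. On these data alone, it remains open whether the ring matters or whether the sulfur link alone is enough. A methylsulfanyl group or an amine in place of chloro would test this.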